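One Carbonyl Substituent Exchanged on a Shared Core

The compounds below may be only part of what the source reports. "The series", "measured", "known", "first", "only" and "open" are said of these compounds alone.

Compound 1 `COc1cc(-c2nn(-c3cccc(NC(=O)Nc4ccc(Cl)c(Cl)c4)c3)cc2-c2ccncc2)ccc1Cl` — 845 nM
Compound 2 `COc1cc(-c2nn(-c3cccc(NC(=O)Nc4ccc(Cl)c(C(F)(F)F)c4)c3)cc2-c2ccncc2)ccc1Cl` — 865 nM

In a functional assay on UO-31 cells (Homo sapiens) for inhibition, read by sulforhodamine B assay, with a stated time of 48 h (on this read-out lower numbers stand for stronger inhibition of growth and higher numbers for weaker inhibition of growth), compound 2 gives 865 nM, the higher of the two numbers, though its gap to compound 1 is within the scatter: the step of a 1.0-fold higher number from compound 1 to compound 2 (0.01 log units; within the scatter) came from trifluoromethyl in place of chloro on an aromatic carbon. Compound 3 `COc1cc(-c2nn(-c3cccc(NC(=O)c4ccccc4)c3)cc2-c2ccncc2)ccc1Cl` carries a different change: phenyl in place of (4-chloro-3-(trifluoromethyl)phenyl)amino on a carbonyl carbon. Among the compounds with values here, no measured step bears on this exchange, since the only step recorded touched a substituent on the very ring that now leaves, and it was within the scatter. The change to compound 3 removes that whole ring and its donor, a far larger alteration than the one measured, so for compound 3 weaker growth inhibition is expected in this assay, with wide uncertainty. Compound 3 is estimated at 2500 nM, between 800 nM and 8000 nM. This estimate means an expected step of a 2.9-fold higher number from compound 2 to compound 3 (0.46 log units; beyond the scatter).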

Compound 3, concentration for 50% growth inhibition: 638 nM
The estimate for compound 3 lay 3.9-fold (0.59 log units) above the measured number, and the stated range ends above it.
By their numbers in this assay, from the lowest: compounds 3, 1 and 2 (each within the scatter of the next).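

Exchanging (4-chloro-3-(trifluoromethyl)phenyl)amino for phenyl on the carbonyl carbon gives a 1.4-fold lower number from compound 2 to compound 3 (0.13 log units; within the scatter) and exchanging (3,4-dichlorophenyl)amino for phenyl gives a 1.3-fold lower number from compound 1 to compound 3 (0.12 log units; within the scatter) in this assay on the shared core. Within the data shown here, the earlier step altered only one substituent on the ring, whereas here the whole group leaves, with its ring substituents and its hydrogen-bond donor, and a plain phenyl enters, yet all three numbers stay within the scatter of one another. No supporting measurement is available to explain this result.

The compounds shown leave open whether this carbonyl carbon accepts a group without an aromatic ring, such as a simple amine or a short alkyl chain. They also leave open whether a methoxy or a carboxylic acid on the entering phenyl would shift the number beyond the scatter.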